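Moving from 3-Chlorophenyl to 4-Methylphenyl on the Sulfonyl

This account rests on a few compounds, and the source may have more. Where it says the series, first, only, none or still open, it means among the compounds named here.

Measured compounds:
compound 1, `O=C(NCc1ccc(CNS(=O)(=O)c2cccc(Cl)c2)cc1)c1ccc(CNc2ncccn2)cc1`, gives 1 nM
compound 2, `Cc1ccccc1S(=O)(=O)NCc1ccc(CNC(=O)c2ccc(CNc3ncccn3)cc2)cc1`, gives 10 nM
compound 3, `Cc1ccc(S(=O)(=O)NCc2ccc(CNC(=O)c3ccc(CNc4ncccn4)cc3)cc2)cc1`, not yet measured

Among the measured compounds shown here, in an assay on MDA-MB-231 cells for binding affinity to C-X-C chemokine receptor type 4 (Homo sapiens), read by microscopy, with stated times of 10 min and 30 min (on this read-out higher numbers stand for an effect only at larger amounts of compound and lower numbers for an effect already at smaller amounts), compound 1 stands at the lowest number of the two measured, with compound 2 as its only neighbour. For the measured compounds named here, the one recorded step between them, a 10-fold higher number from compound 1 to compound 2 (1.00 log units; beyond the scatter), is the sole guide available here.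

Compound 3 is built from compound 1 by the change (4-methylphenyl in place of 3-chlorophenyl on a sulfonyl sulfur). Compound 2 differs from compound 1 at the same place, but with a 2-methylphenyl entering; that step lies beyond the scatter. Whether the 4-methylphenyl of compound 3 behaves like the 2-methylphenyl of compound 2 is not shown by any measured pair, so the expectation is a rise in number of roughly the size seen for compound 2, with wide uncertainty.

For compound 3 the expected step from compound 1 is a 5.0-fold higher number from compound 1 to compound 3 (0.70 log units; beyond the scatter). Compound 3 is therefore estimated at 5 nM, within a range from 1 nM to 30 nM.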

Compound 3, effective concentration (reported as EC, without a stated level of effect): 100 nM
The estimate for compound 3 lay 20-fold (1.30 log units) below the measured number; the whole stated range lies below it.
By their numbers in this assay, from the lowest: compound 1; then compound 2; then compound 3.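

In this assay the place on the sulfonyl sulfur proves far more sensitive than compound 2 alone could show, as replacing 3-chlorophenyl with 4-methylphenyl gives a 100-fold higher number from compound 1 to compound 3 (2.00 log units; beyond the scatter) and this is the largest step in the set. Exchanging 2-methylphenyl for 4-methylphenyl gives a 10-fold higher number from compound 2 to compound 3 (1.00 log units; beyond the scatter) and so shows that the two methylphenyl groups are not interchangeable here, even though they have the same heavy-atom count. Among these three compounds, the 3-chlorophenyl of compound 1 therefore gives the lowest number, and both methylphenyl groups give clearly higher ones. Nothing available here explains these differences.

Each methylphenyl compound differs from compound 1 both in the group carried on the ring and in its location, so these compounds cannot show how much each of those two changes contributes. A 3-methylphenyl or a 4-chlorophenyl on the same sulfonyl sulfur would help separate them, while a plain phenyl would show how the ring behaves with neither chlorine nor methyl.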